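Compound 2 takes up a 2,4-dichloropyridin-3-yl group

The source may hold more compounds than are shown below. What is called first, only, known or untested is meant among the compounds shown, and "the series" means these compounds.

Of the compounds shown here, three have so far been measured in a physicochemical assay for lipophilicity, using the shake flask method (on this read-out higher numbers stand for higher lipophilicity and lower numbers for lower lipophilicity), and give these values.

Compound 1 `C[C@H](Oc1ccc(NC(=O)CC(=O)O)c(C2CC2)c1)c1c(Cl)ccc(F)c1Cl` gives 1.9

Compound 2 `C[C@H](Oc1ccc2ncc(/C=C/C(=O)O)c(C3CC3)c2c1)c1c(Cl)ccc(N)c1Cl` gives 2.8

Compound 3 `C[C@H](Oc1nccc(N(c2nc(C(=O)O)cs2)C2CC2)n1)c1c(Cl)ccc(F)c1Cl` gives 2.6

These three differ from one another in more than one place, so they show no single change on its own. Compound 1 lies lower than compound 2 by more than the scatter, while compound 3 and compound 2 agree within it.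

The next structure, compound 4 `C[C@H](Oc1ccc2ncc(/C=C/C(=O)O)c(C3CC3)c2c1)c1c(Cl)ccnc1Cl`, departs from compound 2 in one place only. The change is a group of 8 heavy atoms (5 carbon, 1 nitrogen, 2 chlorine; one six-membered aromatic ring with 1 hetero atom) in place of a group of 9 heavy atoms (6 carbon, 1 nitrogen, 2 chlorine; one six-membered aromatic ring of carbon only), on a saturated chain carbon bound to an oxygen on an aromatic ring and a saturated chain carbon and the entering group is named 2,4-dichloropyridin-3-yl. Among the compounds with values here, no measured pair shows this change, so the expectation starts from compound 2 at 2.8 and from the structures alone. A small downward step in this assay is expected, none beyond the scatter. The estimated size is a number 0.10 log units lower from compound 2 to compound 4 (within the scatter) in this expectation. For compound 4 the estimated value is 2.7 (expected range 2.2 to 3.2).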

Compound 4, distribution coefficient: 2.3
Compound 4: middle estimate off by 0.40 log units, on the high side; the measured number falls inside the stated range.
By their numbers in this assay, from the lowest: compound 1; then compounds 4, 3 and 2 (each within the scatter of the next, the first and the last beyond it).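

In this assay, within the data shown here, the first single change that can be read on its own is the exchange on the saturated chain carbon bound to an oxygen on an aromatic ring and a saturated chain carbon, which gives a number 0.50 log units lower from compound 2 to compound 4 (beyond the scatter). The six-membered aromatic ring of carbon only gives way to 2,4-dichloropyridin-3-yl, so this place is shown to register in the read-out, with the entering group counting 0 hydrogen-bond donors against 1 for the group that leaves. Nothing measured here accounts for the size or direction of this step.

The compounds shown leave open whether this step would recur on the core of compound 1 or compound 3, which carry a different group at this place. They also leave open how a pyrimidine ring or a methoxy group on the ring would read there.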